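Chloro-to-hydroxy swap on two paw edema cores

The source may report more compounds than this note shows. Statements on the series, on what has been measured and on what is new or still open speak of the compounds shown alone.

Measured so far in a functional assay on the whole organism (strain albino) for inhibition, with Rattus norvegicus as the target, read by paw edema, with stated times of 1 h and 3 h, at a dose of 100 mg/kg by the oral route; on this read-out lower numbers stand for a weaker effect and higher numbers for a stronger effect at the one dose given:
compound 1 `O=C(CSc1nc(-c2ccc(Cl)cc2)c(C(=O)O)c(=O)[nH]1)Nn1c(COc2ccc(Cl)cc2Cl)nc2ccccc2c1=O` gives 61.4%
compound 2 `O=C(CSc1nc(-c2ccc(O)cc2)c(C(=O)O)c(=O)[nH]1)Nn1c(COc2ccc(Cl)cc2Cl)nc2ccccc2c1=O` gives 38.6%
compound 3 `Cn1c(SCC(=O)Nn2c(COc3ccc(Cl)cc3Cl)nc3ccccc3c2=O)nc(-c2ccc(Cl)cc2)c(C#N)c1=O` gives 73.7%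

Compounds 1 and 2 share one core, compound 3 sits on another core; how the two cores differ is not broken down here. Among the three measured compounds, compound 3 stands highest in this assay, beyond the scatter against both others. From compound 1 to compound 2 the change is hydroxy in place of chloro on an aromatic carbon, and it gives a number 22.8 percentage points lower from compound 1 to compound 2 (beyond the scatter). Compound 4 `Cn1c(SCC(=O)Nn2c(COc3ccc(Cl)cc3Cl)nc3ccccc3c2=O)nc(-c2ccc(O)cc2)c(C#N)c1=O` carries the same change on the core of compound 3: hydroxy in place of chloro on an aromatic carbon. The place of the change reads the same in both pairs, so it is taken as the same change, only on a different core. Among the compounds with values here, the step on the second core is expected to repeat in direction and roughly in size, resting on a number 22.8 percentage points lower from compound 1 to compound 2 (beyond the scatter) as the only example of this change, so the expected step is a number 21.7 percentage points lower from compound 3 to compound 4 (beyond the scatter). Compound 4 is therefore expected to give 52% in this assay. With a single prior example, compound 4 is estimated to fall between 38% and 66%.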

Compound 4, a percentage reported as inhibition, in the whole organism at one dose (the size of the read-out at that dose, not a potency): 86%
The estimate for compound 4 lay 34 percentage points below the measured number, outside the stated range (above it).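

On the core of compound 3, the change from 4-chlorophenyl to 4-hydroxyphenyl gives a number 12.3 percentage points higher from compound 3 to compound 4 (beyond the scatter) in this assay. Set beside the step on the core of compound 1, the same change runs in the opposite direction: the same change on two cores in this assay, a number 22.8 percentage points lower (beyond the scatter) from compound 1 to compound 2 and a number 12.3 percentage points higher (beyond the scatter) from compound 3 to compound 4, 35.1 percentage points apart, beyond the scatter of two such steps The step therefore cannot be carried from one core to the other in this series as a fixed increment or even as a fixed direction, but this rests on one pair per core, each read as the size of the effect at a single dose rather than as a potency, and it does not show which difference between the two cores goes with the reversal.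

Going by these compounds, whether a methoxy or an amino group in the place of the chloro would follow the hydroxy on either core remains open. Also open, on these data alone, is how the step would behave on a core that differs from the core of compound 1 in only one place, for example with a nitrile in place of the carboxylic acid alone.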